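Cyclohexyl to Phenyl on the Ether Chain of Compound 1

The compounds below may be only part of what the source reports. "The series", "measured", "known", "first", "only" and "open" are said of these compounds alone.

Compound 1 `O=c1c(Cc2coc3cccc(OCC4CCCCC4)c3c2=O)coc2ccccc12` was tested in a functional assay on MDA-MB-231 cells (Homo sapiens) for antiproliferative activity, read by XTT assay (on this read-out lower numbers stand for stronger inhibition and higher numbers for weaker inhibition), where compound 1 gives 4110 nM. Among the measured compounds shown here, of the two numbers recorded so far, that of compound 1 is the larger, yet the gap to its only neighbour stays within the scatter. That neighbour, compound 2 `O=c1c(Cc2coc3cccc(OCC4CCCCC4)c3c2=O)coc2cc(O)ccc12`, gives 3220 nM in this assay; the step is a 1.3-fold lower number from compound 1 to compound 2 (0.11 log units; within the scatter), brought about by a hydroxy in place of hydrogen on an aromatic carbon.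

Compound 3 `O=c1c(Cc2coc3cccc(OCc4ccccc4)c3c2=O)coc2ccccc12` is the next compound in line. It differs from compound 1 by phenyl in place of cyclohexyl on a saturated chain carbon bound to an oxygen on an aromatic ring. For the measured compounds named here, the one measured step touches a different place on the shared core and says nothing about exchanging the ring on the ether chain. Going by the values given here, with no step that bears on this change, the expectation for compound 3 is a number close to that of compound 1, with no step beyond the scatter in either direction, so that the estimated step is a 1.0-fold lower number from compound 1 to compound 3 (0.01 log units; within the scatter). The value expected for compound 3 in this assay is therefore 4000 nM, within a range from 1500 nM to 11000 nM.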

Compound 3, half-maximal inhibitory concentration: > 10000 nM
Compound 3 was reported as a limit; the forecaster's own chance of this, stated with the estimate: 5%; at least 2.5-fold (0.39 log units) between middle value and limit.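

In this assay, the ring on the ether chain turns out not to be interchangeable: phenyl in place of cyclohexyl on a saturated chain carbon bound to an oxygen on an aromatic ring gives an at least 2.4-fold higher number from compound 1 to compound 3 (0.38 log units; beyond the scatter). Cyclohexyl and phenyl match in their counts of heavy atoms, hydrogen-bond donors and hydrogen-bond acceptors, and they differ in that one ring is non-aromatic and the other aromatic, so this place on the molecule responds to a change that the earlier step, a 1.3-fold lower number from compound 1 to compound 2 (0.11 log units; within the scatter), made elsewhere on the shared core, could not have revealed. The value of compound 3 is a limit of the assay and not a number: the limit of > 10000 nM in this assay, at which 1 of the 3 values shown sits.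

The compounds shown leave open whether the number of compound 1 depends on a saturated carbon ring as such, which cyclopentyl, a piperidine ring carrying an amine, or a longer chain between the oxygen and the cyclohexyl could help to settle. They also leave open whether the hydroxy of compound 2 would shift the number of a benzyloxy compound in the same way as it does with cyclohexylmethoxy.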